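Adding bromo to compound 3

A few compounds are considered here, and "the series" means these few. Any claim that something is new, unique, unknown or untested is made for them only; others in the source may bear on it.

In a functional assay on MCF7 cells (Homo sapiens) for cytotoxicity, read by sulforhodamine B assay, with a stated time of 48 h (a lower number here means a stronger inhibitor, a higher number a weaker inhibitor), compound 3 `O=C(c1cccnc1)c1ccccc1O` gives 24600 nM. For the measured compounds named here, compound 2 `O=C(c1cccnc1)c1cc(F)ccc1O` gives 27800 nM, so these two stand level and are the only true numbers so far. Compound 1 `C=CCOc1cc(Br)ccc1C(=O)c1cccnc1` reaches only a limit of the assay, > 100000 nM.

Compound 4 `O=C(c1cccnc1)c1ccc(Br)cc1O` carries one change from compound 3: bromo in place of hydrogen on an aromatic carbon. Going by the values given here, the only measured step of this kind is a 1.1-fold lower number from compound 2 to compound 3 (0.05 log units; within the scatter), where hydrogen replaces fluoro. Among the compounds with values here, it involves a different halogen, so it is only a loose guide, and no measured step tests bromo directly. Based on that small step, a shift a 1.1-fold lower number from compound 3 to compound 4 (0.05 log units; within the scatter) is expected, which stays within the scatter. For compound 4, the estimated value is 22000 nM, with an expected range of 8000 nM to 55000 nM.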

Compound 4, half-maximal inhibitory concentration: > 100000 nM
Compound 4: only a limit was reported (the forecaster's own chance of this, stated with the estimate: 12%); middle value at least 4.5-fold (0.65 log units) away from the limit.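

In this assay, for the compounds shown here, bromo on this aromatic carbon, meta to a hydroxy group, gives the first readable step beyond the scatter: an at least 4.0-fold higher number from compound 3 to compound 4 (0.60 log units; beyond the scatter). The small step seen with fluoro on compound 2 therefore did not carry over to this change. Compound 4 sits at a limit of the assay, so the step gives only a minimum size: the limit of > 100000 nM in this assay, at which 2 of the 4 values shown sit.

The step between compound 1 and compound 4 joins two limits and cannot be read. Going by these compounds, whether an amine or a methyl group on this same aromatic carbon would also raise the number stays open.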